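Hydroxy to carboxy on the amide side chain of compound 2

The source may report more compounds than this note shows. Statements on the series, on what has been measured and on what is new or still open speak of the compounds shown alone.

Measured compounds:
compound 1, `CCC(CC)(c1ccc(OCC(=O)C(C)(C)C)c(C)c1)c1ccc(C(=O)NCC(=O)OC)n1C`: 23 nM
compound 2, `CCn1c(C(=O)NCCO)ccc1C(CC)(CC)c1ccc(OCC(O)C(C)(C)C)c(C)c1`: 5640 nM

The readout throughout is an assay on HL-60 cells for agonist activity at vitamin D3 receptor (Homo sapiens), with a stated time of 96 h; a lower number here means that less compound is needed, a higher number that more compound is needed for the effect. Of the two measured compounds, compound 2 stands with the highest number; its nearest neighbour, compound 1, gives 23 nM, a gap that lies well beyond the scatter. Compound 3, `CCn1c(C(=O)NCCC(=O)O)ccc1C(CC)(CC)c1ccc(OCC(O)C(C)(C)C)c(C)c1`, is not yet measured. It differs from compound 2 by carboxy in place of hydroxy on a saturated chain carbon, two bonds along the chain from an amide-type nitrogen. Among the compounds with values here, no step between measured compounds bears on this change, so nothing among the measured values tells which way it should go. Compound 3 is therefore expected to give a number close to that of compound 2, with the step from compound 2 to compound 3 estimated as a 1.3-fold lower number from compound 2 to compound 3 (0.10 log units; within the scatter), no larger than the scatter. For compound 3 the estimated value in this assay is 4500 nM, with a range from 900 nM to 22000 nM.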

Compound 3, half-maximal effective concentration: 33200 nM
Beside the measured number, compound 3's estimate is 7.4-fold (0.87 log units) below it, and the stated range ends below it.
By their numbers in this assay, from the lowest: compound 1; then compound 2; then compound 3.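

Within the data shown here, the pair of compound 2 and compound 3 gives the first reading at this place, a saturated chain carbon two bonds along the chain from an amide-type nitrogen. In this assay the change from hydroxy to carboxy gives a 5.9-fold higher number from compound 2 to compound 3 (0.77 log units; beyond the scatter) and so shows that what sits here matters to this read-out, with more compound needed once carboxy enters. Nothing at hand accounts for this step.

Carboxy brings three heavy atoms where hydroxy had one, and this single pair cannot separate the identity of the group from its size. As far as these compounds go, an amine or a longer chain ending in hydroxy at this place would help to settle that, and whether the same change would act alike on the core of compound 1 also stays open.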